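Swapping the isoquinoline for a fused five-six ring

A few compounds are considered here, and "the series" means these few. Any claim that something is new, unique, unknown or untested is made for them only; others in the source may bear on it.

In an assay on isolated protein for inhibition of Fatty-acid amide hydrolase 1 (Homo sapiens), with a stated time of 60 min (a higher number here means a weaker inhibitor, a lower number a stronger inhibitor), compound 2 `O=C(Nc1cncc2ccccc12)N1CCN(Cc2cccc(Oc3ccc(Cl)cc3)c2)CC1` gives 6.7 nM, the lowest number of the three measured compounds. Compound 1 `O=C(Nc1cccc2cn[nH]c12)N1CCN(Cc2cccc(Oc3ccc(Cl)cc3)c2)CC1` gives 1300 nM, and compound 3 `O=C(Nc1cccn2ccnc12)N1CCN(Cc2cccc(Oc3ccc(Cl)cc3)c2)CC1` gives 310 nM. Both comparisons point one way: a 190-fold lower number from compound 1 to compound 2 (2.29 log units; beyond the scatter), and a 46-fold higher number from compound 2 to compound 3 (1.67 log units; beyond the scatter). Compound 4 `O=C(Nc1ccc2nccn2c1)N1CCN(Cc2cccc(Oc3ccc(Cl)cc3)c2)CC1` is not yet measured; it differs from compound 2 in that (a group of 9 heavy atoms (7 carbon, 2 nitrogen; one five-membered aromatic ring with 2 hetero atoms, one six-membered aromatic ring with 1 hetero atom) in place of a group of 10 heavy atoms (9 carbon, 1 nitrogen; one six-membered aromatic ring of carbon only, one six-membered aromatic ring with 1 hetero atom), on an amide-type nitrogen). The group entering compound 4 has the same counts of atoms, rings and acceptors as the group in compound 3, joined to the urea nitrogen through a different ring atom. A markedly weaker result is therefore expected for compound 4 because the closest measured step was a 46-fold higher number from compound 2 to compound 3 (1.67 log units; beyond the scatter), so the expected step is a 22-fold higher number from compound 2 to compound 4 (1.35 log units; beyond the scatter). Compound 4 is estimated at 150 nM, within a range of 30 nM to 800 nM.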

Compound 4, half-maximal inhibitory concentration: 100 nM
Compound 4: middle estimate off by 1.5-fold (0.18 log units), on the high side; the range from low to high includes it.
By their numbers in this assay, from the lowest: compound 2; then compound 4; then compound 3; then compound 1.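

The step of a 3.1-fold lower number from compound 3 to compound 4 (0.49 log units; beyond the scatter) shows that, with the same counts of atoms and rings, the ring atom joined to the amide-type nitrogen changes the result on its own. Still, a gap of a 15-fold higher number from compound 2 to compound 4 (1.17 log units; beyond the scatter) remains, so this group does not reach the level of isoquinolin-4-yl, while a 13-fold lower number from compound 1 to compound 4 (1.11 log units; beyond the scatter) places it well clear of 1H-indazol-7-yl. Nothing available explains these gaps. As far as these compounds go, whether a plain phenyl or a quinolin-3-yl group on the same nitrogen would match compound 2 stays open.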